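Bromo in place of hydrogen on compound 2

The source may report more compounds than this note shows. Statements on the series, on what has been measured and on what is new or still open speak of the compounds shown alone.

In a functional assay on ACHN cells (Homo sapiens) (a lower number here means a stronger inhibitor of growth, a higher number a weaker inhibitor of growth), compound 1 `O=S(=O)(/C=C/c1ccc(Cl)c(Cl)c1)Cc1ccc(Nc2ncnc3ccccc23)cc1` gives 28000 nM, while compound 2 `O=S(=O)(/C=C/c1ccc(Cl)cc1Cl)Cc1ccc(Nc2ncnc3ccccc23)cc1` gives 100 nM, the lower of the two numbers. Compound 3 `O=S(=O)(/C=C/c1ccc(Cl)cc1Cl)Cc1ccc(Nc2ncnc3ccc(Br)cc23)cc1` differs from compound 2 by bromo in place of hydrogen on an aromatic carbon, which is bromo in place of hydrogen on an aromatic carbon. Among the measured compounds shown here, no measured step covers this change. The only one, a 280-fold lower number from compound 1 to compound 2 (2.45 log units; beyond the scatter), concerns the dichlorophenyl group, though its large size warns that one change can matter greatly here. The expected step, a 1.5-fold higher number from compound 2 to compound 3 (0.18 log units; within the scatter), is therefore none beyond the scatter, in either direction. For compound 3 the estimated value is 150 nM, with an expected range of 25 nM to 1500 nM.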

Compound 3, concentration for 50% growth inhibition: 100 nM
The estimate for compound 3 lay 1.5-fold (0.18 log units) above the measured number; low and high end bracket the measured number.
By their numbers in this assay, from the lowest: compounds 2 and 3 (each within the scatter of the next); then compound 1.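

In this assay, bromo in place of hydrogen on an aromatic carbon of the shared core brings no change at the digits printed from compound 2 to compound 3 (within the scatter). Among the compounds shown here, this aromatic carbon therefore accepts a bromine atom with no step beyond the scatter, whereas the earlier compounds showed only a large step at the dichlorophenyl group. Nothing at hand explains this result.

The compounds shown leave open whether an amine, a methoxy group or a carboxylic acid on this carbon would match bromo. They also leave open whether bromo would do the same alongside the 3,4-dichlorophenyl group of compound 1.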